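Working notes: added methoxy and cytotoxicity at one concentration

The source may hold more compounds than are shown below. What is called first, only, known or untested is meant among the compounds shown, and "the series" means these compounds.

Measured so far:
compound 1, `COc1ccc(C(=O)/C=C/c2cc(-c3cc(OC)c(OC)c(OC)c3)n[nH]2)cc1OC`: 86%
compound 2, `COc1cc(-c2cc(/C=C/C(=O)c3ccc(F)c(F)c3)[nH]n2)cc(OC)c1OC`: 92%

In a functional assay on OVCAR-5 cells (Homo sapiens) for cytotoxicity, read by sulforhodamine B assay, with a stated time of 48 h, tested at 1 uM (a lower number here means a stronger effect, a higher number a weaker effect of the compound at the concentration tested), compound 1 gives 86% and compound 2 gives 92%. Compound 1 holds the lower of the two numbers, but the step of a number 6 percentage points higher from compound 1 to compound 2 (within the scatter) lies within the scatter, so the two cannot be set apart.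

Compound 3, `COc1cc(C(=O)/C=C/c2cc(-c3cc(OC)c(OC)c(OC)c3)n[nH]2)cc(OC)c1OC`, is not yet measured. It differs from compound 1 by methoxy in place of hydrogen on an aromatic carbon. For the measured compounds named here, the only measured step, a number 6 percentage points higher from compound 1 to compound 2 (within the scatter), touches the same ring but exchanges its whole substitution pattern, and it stayed within the scatter; no measured step matches the present change, so the data give it no direct bearing. For compound 3 in this assay the step of a number 1 percentage points lower from compound 1 to compound 3 (within the scatter) is expected to remain within the scatter. Compound 3 is therefore estimated at 85%, in the range 72% to 98%.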

Compound 3, a percentage reported as activity, at one concentration (the size of the read-out at that concentration, not a potency): 89%
Compound 3: middle estimate off by 4 percentage points, on the low side, and the stated range covers the measured number.
By their numbers in this assay, from the lowest: compounds 1, 3 and 2 (each within the scatter of the next).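

In this assay methoxy in place of hydrogen on an aromatic carbon, ortho to a methoxy group and meta to a large group, gives a number 3 percentage points higher from compound 1 to compound 3 (within the scatter) and so produces no readable change at this position. The earlier step exchanged the whole substitution pattern of this ring, whereas this one isolates a single added methoxy, and it too stays within the scatter. Nothing at hand bears on why the added methoxy leaves the read-out unchanged.

From the compounds shown here alone, it remains open whether an amine, a carboxylic acid or a longer chain such as butoxy at this position would move the number beyond the scatter. Going by these compounds, it also remains open whether any change on this ring can separate compounds at the single concentration tested.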